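Swapping nitro for chloro on compound 3

The compounds below may be only part of what the source reports. "The series", "measured", "known", "first", "only" and "open" are said of these compounds alone.

Measured in a functional assay on UACC-62 cells (Homo sapiens) for cytotoxicity, read by sulforhodamine B assay; a higher number here means a weaker inhibitor of growth, a lower number a stronger inhibitor of growth:
Compound 1 `CC1=CC[C@@H]([C@@](C)(O)CCCC(C)(C)NC(=S)NN)CC1`: > 100000 nM, a limit of the assay and not a number
Compound 2 `CC1=CC[C@@H]([C@@](C)(O)CCCC(C)(C)NC(=S)N/N=C\c2ccccc2[N+](=O)[O-])CC1`: 16600 nM
Compound 3 `CC1=CC[C@@H]([C@@](C)(O)CCCC(C)(C)NC(=S)N/N=C\c2cccc([N+](=O)[O-])c2)CC1`: 24700 nM

Compound 3 cannot be told apart from compound 2, since 3-nitrophenyl in place of 2-nitrophenyl gave a 1.5-fold higher number from compound 2 to compound 3 (0.17 log units; within the scatter). Compound 4 `CC1=CC[C@@H]([C@@](C)(O)CCCC(C)(C)NC(=S)N/N=C\c2cccc(Cl)c2)CC1` carries chloro in place of nitro on an aromatic carbon. Within the data shown here, that measured step is the only one between two compounds carrying a substituted ring, and no measured compound carries chloro. The expectation therefore starts from compound 3 at 24700 nM, with no step beyond the scatter in this assay and no favoured direction. The expected step is a 1.1-fold lower number from compound 3 to compound 4 (0.05 log units; within the scatter). For compound 4 the estimated value is 22000 nM, within an expected range of 10000 nM to 55000 nM.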

Compound 4, concentration for total growth inhibition: 18100 nM
Estimate against measurement, compound 4: 1.2-fold (0.08 log units) above; measured number inside the range.
By their numbers in this assay, from the lowest: compounds 2, 4 and 3 (each within the scatter of the next). At a limit, above all of these: compound 1.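

In this assay, 3-chlorophenyl and 3-nitrophenyl cannot be told apart, with a 1.4-fold lower number from compound 3 to compound 4 (0.14 log units; within the scatter), and 3-chlorophenyl in place of 2-nitrophenyl gave a 1.1-fold higher number from compound 2 to compound 4 (0.04 log units; within the scatter). At this place on the aromatic ring, then, the nitro group can give way to chloro with no change beyond the scatter. The step from the bare end of the core gave an at least 5.5-fold lower number from compound 1 to compound 4 (0.74 log units; beyond the scatter), and its size is only a bound: the limit of > 100000 nM in this assay, at which 1 of the 4 values shown sits.

The compounds shown leave open whether an amine or a carboxylic acid on this ring would shift the number beyond the scatter. They also leave open whether a plain phenyl ring would match these values.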